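Three Measured Analogues and a Fourth to Come

The source may hold more compounds than are shown below. What is called first, only, known or untested is meant among the compounds shown, and "the series" means these compounds.

Three compounds share one core and differ only in the group that sits on a carbon with a double bond to nitrogen. Compound 1 `COc1cc(/C=N/NC(=O)Nc2ccc(Oc3ccnc(-c4nncn4CCN(C)C)c3)c(F)c2)cc(OC)c1OC` carries 3,4,5-trimethoxyphenyl there, and in a functional assay on HT-29 cells (Homo sapiens) for cytotoxicity, read by MTT assay, with a stated time of 72 h (on this read-out lower numbers stand for stronger inhibition and higher numbers for weaker inhibition), compound 1 gives 3620 nM. Compound 2 `CN(C)CCn1cnnc1-c1cc(Oc2ccc(NC(=O)N/N=C/c3cccc(Cl)c3Cl)cc2F)ccn1` carries 2,3-dichlorophenyl, and in this assay compound 2 gives 130 nM. Compound 3 `CN(C)CCn1cnnc1-c1cc(Oc2ccc(NC(=O)N/N=C/c3c(O)ccc4ccccc34)cc2F)ccn1` carries 2-hydroxynaphthalen-1-yl, and in this assay compound 3 gives 670 nM, the second highest of the three numbers: it stands a 5.2-fold higher number from compound 2 to compound 3 (0.71 log units; beyond the scatter) and a 5.4-fold lower number from compound 1 to compound 3 (0.73 log units; beyond the scatter). The widest gap in the set is a 28-fold lower number from compound 1 to compound 2 (1.44 log units; beyond the scatter).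

Compound 4 `Cc1cc(/C=N/NC(=O)Nc2ccc(Oc3ccnc(-c4nncn4CCN(C)C)c3)c(F)c2)cc(C)c1O` is not yet measured. It differs from compound 3 in one place: 4-hydroxy-3,5-dimethylphenyl in place of 2-hydroxynaphthalen-1-yl on a carbon with a double bond to nitrogen. Going by the values given here, no measured step swaps the naphthol for a phenol, so the three steps only show that this position tolerates changes of large as well as modest size in either direction. Since the incoming group is a substituted single ring, as in compound 1 with 3620 nM and compound 2 with 130 nM, the expected value for compound 4 is taken between those two, and the step of a 2.2-fold higher number from compound 3 to compound 4 (0.35 log units; beyond the scatter) is the estimated outcome. Compound 4 is thus expected to give 1500 nM in this assay, within a range of 400 nM to 6000 nM.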

Compound 4, half-maximal inhibitory concentration: 1220 nM
Estimate against measurement, compound 4: 1.2-fold (0.09 log units) above; the measured number falls inside the stated range.
By their numbers in this assay, from the lowest: compound 2; then compounds 3 and 4 (each within the scatter of the next); then compound 1.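

In this assay, going by these compounds alone, exchanging the two-ring 2-hydroxynaphthalen-1-yl for the single-ring 4-hydroxy-3,5-dimethylphenyl gives a 1.8-fold higher number from compound 3 to compound 4 (0.26 log units; within the scatter), the first step at this position that stays within the scatter, so here the read-out does not separate the two groups despite the difference in aromatic rings. The same single-ring group is separated from the other two single-ring groups, with a 9.4-fold higher number from compound 2 to compound 4 (0.97 log units; beyond the scatter) and a 3.0-fold lower number from compound 1 to compound 4 (0.47 log units; beyond the scatter), so among compounds 1, 2 and 4 having one aromatic ring at this position does not by itself fix the number, and the substituents on that ring go with differences beyond the scatter. No accompanying measurement offers an explanation for these differences or for the lack of one between compound 3 and compound 4.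

The compounds shown leave open what the hydroxy group contributes, for no pair here differs by that group alone. They also do not show how the read-out would respond to an amine or a carboxylic acid on the ring at this position, or to longer chains in place of the two methyl groups.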